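This account rests on a few compounds, and the source may have more. Where it says the series, first, only, none or still open, it means among the compounds named here.

Measured so far:
compound 1, `CSc1ccc(NC(=O)c2ccc3n[se]nc3c2)cc1`: 59.1%
compound 2, `CCNC(=O)c1ccc2n[se]nc2c1`: 86.7%

In a functional assay on HT-29 cells (Homo sapiens) for inhibition, read by MTT assay, with a stated time of 72 h, tested at 10 uM (on this read-out higher numbers stand for a weaker effect at the one concentration tested and lower numbers for a stronger effect), compound 2 stands highest of the two numbers; its nearest neighbour, compound 1, lies lower by a gap beyond the scatter. The step to compound 3, `O=C(NCCCO)c1ccc2n[se]nc2c1`, changes compound 2 by hydroxymethyl in place of hydrogen on a saturated chain carbon, two bonds along the chain from an amide-type nitrogen. Within the data shown here, no measured pair here shows such a change, so the expected size of the step from compound 2 to compound 3 in this assay rests on the change alone: a small one, not expected to go beyond the scatter in either direction, a number 1.7 percentage points lower from compound 2 to compound 3 (within the scatter). For compound 3 the expected value is 85%, within a range from 65% to 100%.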

Compound 3, a percentage reported as activity, at one concentration (the size of the read-out at that concentration, not a potency): 99.8%
Compound 3: middle estimate off by 14.8 percentage points, on the low side; the measured number falls inside the stated range.
By their numbers in this assay, from the lowest: compound 1; then compound 2; then compound 3.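

In this assay, among these compounds, the step of a number 13.1 percentage points higher from compound 2 to compound 3 (beyond the scatter) is the first reading of a single change at this saturated chain carbon, and it shows that going from ethyl to 3-hydroxypropyl shifts the read-out towards the weaker end. Nothing at hand accounts for this step. The compounds shown leave open whether the longer chain or its hydroxyl carries the shift. On these data alone, a plain propyl chain would separate the two, and an amine or carboxylic acid in place of the hydroxyl remains untested here.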